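From oxolan-2-yl to tert-butoxy at the limit

This account rests on a few compounds, and the source may have more. Where it says the series, first, only, none or still open, it means among the compounds named here.

Measured in a physicochemical assay for lipophilicity, at pH 7.4; on this read-out lower numbers stand for lower lipophilicity and higher numbers for higher lipophilicity:
- compound 1 `Cc1cc(C(N)=O)nn1Cc1cc(Cl)ccc1OCc1ccccc1`: 3.7
- compound 2 `Cc1cc(C(=O)NCc2ccccc2)nn1Cc1cc(Cl)ccc1OCc1ccccc1`: > 3.7 (a limit)
- compound 3 `Cc1cc(NC(=O)C2CCCO2)nn1Cc1cc(Cl)ccc1OCc1ccccc1`: > 3.7 (a limit)

Compound 3 gives only a limit, > 3.7, and not a number. Compound 4 `Cc1cc(NC(=O)OC(C)(C)C)nn1Cc1cc(Cl)ccc1OCc1ccccc1` differs from it in one place: tert-butoxy in place of oxolan-2-yl on a carbonyl carbon. Here tert-butoxy stands in place of oxolan-2-yl on a carbonyl carbon. Going by the values given here, no measured step makes this exchange. Among the compounds with values here, the steps that bear on it are a number no lower from compound 1 to compound 3 (the limit leaves the size open) and a number no lower from compound 1 to compound 2 (the limit leaves the size open), and neither has a readable size. The same holds for a step that the two limits leave unreadable from compound 2 to compound 3. The best remaining guide is the limit of > 3.7 in this assay, at which 2 of the 3 values shown sit. In this assay, as far as these compounds go, no step beyond the scatter can be expected with confidence, and its direction stays open. The expected change is a step that the limit leaves unreadable from compound 3 to compound 4. The estimate for compound 4 is 4, with an expected range of 3.7 to 4.6.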

Compound 4, distribution coefficient: > 3.7
Compound 4 was reported as a limit (the forecaster's own chance of this, stated with the estimate: 85%); the middle value lies beyond the limit too.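

In this assay compound 4 gives > 3.7, which is a limit and not a number. (Tert-butoxycarbonyl)amino in place of carbamoyl on an aromatic carbon gives a number no lower from compound 1 to compound 4 (the limit leaves the size open). Tert-butoxy, which has no ring, replaces the ring-bearing oxolan-2-yl with the same count of heavy atoms, yet the steps to compound 4 from compound 2 and compound 3 cannot be read. The aromatic carbon has now carried three groups that end at this limit, and the values shown gather there: the limit of > 3.7 in this assay, at which 3 of the 4 values shown sit.

As far as these compounds go, how far these compounds lie past the limit stays open. So does whether a carboxylic acid or an amine on that aromatic carbon would give a readable number.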